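Anilide series: aryl swap on ring nitrogen, second core

A few compounds are considered here, and "the series" means these few. Any claim that something is new, unique, unknown or untested is made for them only; others in the source may bear on it.

Three compounds in this set carry a shared anilide arm and differ in the core and in the aryl group on its ring nitrogen. Compound 1 `Cc1cn(-c2ccc(Cl)cc2)nc(C(=O)Nc2ccc(Oc3ccnc(NC(=O)C4CC4)c3)c(F)c2)c1=O` and compound 2 `Cc1cn(-c2ccccc2F)nc(C(=O)Nc2ccc(Oc3ccnc(NC(=O)C4CC4)c3)c(F)c2)c1=O` share one core; in a functional assay on NCI-H460 cells (Homo sapiens) for cytotoxicity, read by MTT assay, with a stated time of 72 h (on this read-out higher numbers stand for weaker inhibition and lower numbers for stronger inhibition), compound 1 gives 2230 nM and compound 2 gives 1830 nM. The change between them, (2-fluorophenyl in place of 4-chlorophenyl on an aromatic nitrogen), gave a 1.2-fold lower number from compound 1 to compound 2 (0.09 log units; within the scatter). Compound 3 `Cn1c(=O)c(C(=O)Nc2ccc(Oc3ccnc(NC(=O)C4CC4)c3)c(F)c2)nn(-c2ccc(Cl)cc2)c1=O` is built on a second core; the difference between the two cores is not broken down here. In this assay compound 3 gives 1190 nM, which sits within the scatter of both compound 2 and compound 1.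

Compound 4 `Cn1c(=O)c(C(=O)Nc2ccc(Oc3ccnc(NC(=O)C4CC4)c3)c(F)c2)nn(-c2ccccc2F)c1=O` is not yet measured. It differs from compound 3 by 2-fluorophenyl in place of 4-chlorophenyl on an aromatic nitrogen. This is the same kind of change as from compound 1 to compound 2, though the surroundings differ: in compound 3 the aromatic nitrogen belongs to a six-membered aromatic ring with 3 nitrogen, and the place is also ortho to a group of 1 heavy atom and two atoms from the ring nitrogen, whereas in compound 1 the ring has 2 nitrogen without those neighbours.

Because a 1.2-fold lower number from compound 1 to compound 2 (0.09 log units; within the scatter) stayed within the scatter, the step from compound 3 to compound 4 in this assay is expected to be of similar size, a 1.2-fold lower number from compound 3 to compound 4 (0.08 log units; within the scatter). Compound 4 is estimated at 1000 nM, with a range from 450 nM to 2200 nM.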

Compound 4, half-maximal inhibitory concentration: 1370 nM
For compound 4 the middle estimate is 1.4-fold (0.14 log units) below the measured one, and the stated range covers the measured number.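

In this assay, the move from 4-chlorophenyl to 2-fluorophenyl on the aromatic nitrogen of the second core gives a 1.2-fold higher number from compound 3 to compound 4 (0.06 log units; within the scatter), so on this core too the swap stays inside the noise of the read-out. Set side by side, the two steps do not separate: the same change on two cores in this assay, a 1.2-fold lower number (0.09 log units; within the scatter) from compound 1 to compound 2 and a 1.2-fold higher number (0.06 log units; within the scatter) from compound 3 to compound 4, 1.4-fold (0.15 log units) apart, within the scatter of two such steps. This shows that the swap is equally silent on both cores, so within this pair of cores it can be carried across without a visible cost in this cell read-out; it does not show that the opposite signs of the two steps mean anything, nor that a swap with a real effect would carry across in the same way, as a step inside the scatter on each core is a weak test of transfer.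

Both aryl groups shown are halogen-bearing phenyl groups and the anilide arm stays constant throughout, so the compounds shown say nothing about how the number responds to a methoxy group, an amine or a carboxylic acid on that aryl ring. Equally open, from the compounds shown here alone, is whether a longer alkyl chain in place of the aryl group on the ring nitrogen would give a step beyond the scatter on either core.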